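Benzamide series: halophenyl piperazine dithiocarbamates in HeLa proliferation

The source may hold more compounds than are shown below. What is called first, only, known or untested is meant among the compounds shown, and "the series" means these compounds.

Measured so far:
compound 1, `Nc1ccccc1NC(=O)c1ccc(CSC(=S)N2CCN(c3ccc(Cl)cc3)CC2)cc1`, 44.8%
compound 2, `CCN(Cc1ccncc1)C(=S)SCc1ccc(C(=O)Nc2ccccc2N)cc1`, 77.7%

Both numbers come from a functional assay on HeLa cells (Homo sapiens) for antiproliferative activity, read by CCK-8 assay, with a stated time of 72 h, tested at 8 uM; a higher number here means a stronger effect of the compound at the concentration tested, a lower number a weaker effect. Compound 1 stands at the lower of the two values recorded in this assay; compound 2 lies higher, and the gap between the two is beyond the scatter. Among the measured compounds shown here, no pair of measured compounds differs in only one place, so no single structural step has a measured size yet.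

Compound 3, `Nc1ccccc1NC(=O)c1ccc(CSC(=S)N2CCN(c3ccccc3F)CC2)cc1`, is the next member. It differs from compound 1 in one place: 2-fluorophenyl in place of 4-chlorophenyl on an amine nitrogen in a ring. The rest of the core of compound 1 is kept unchanged.

For the measured compounds named here, with no measured step of this kind available, only a cautious expectation is possible. The change is expected to move the number for compound 3 by a number 2.8 percentage points lower from compound 1 to compound 3 (within the scatter) in this assay, a shift not beyond the scatter. Compound 3 is therefore estimated at 42% in this assay, with a plausible range from 25% to 60%.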

Compound 3, a percentage reported as inhibition, at one concentration (the size of the read-out at that concentration, not a potency): 59.2%
Estimate against measurement, compound 3: 17.2 percentage points below, within the range that was stated.
By their numbers in this assay, from the lowest: compound 1; then compound 3; then compound 2.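

In this assay, among the compounds shown here, the first measured step falls on the aryl group: 2-fluorophenyl in place of 4-chlorophenyl on an amine nitrogen in a ring gives a number 14.4 percentage points higher from compound 1 to compound 3 (beyond the scatter), a modest change but one beyond the scatter. The read-out therefore responds to this position while the rest of the core of compound 1 stays unchanged, which the earlier pair, differing in more than one place, could not show. The two groups match in heavy-atom count, in having no hydrogen-bond donors or acceptors and in carrying no net charge, so those counts do not tell them apart, and no measurement on hand bears on why the number moves.

The step changes the halogen and its place on the phenyl ring together, so the compounds shown do not separate the contribution of either. Also open, from the compounds shown here alone, is how a plain phenyl or a methoxyphenyl on the same nitrogen would read, and whether any such group would bring the series closer to compound 2, whose structure differs from compound 3 in more than this one place.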